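Methyl for Bromo on the Sulfonyl Aryl of Compound 3

This account rests on a few compounds, and the source may have more. Where it says the series, first, only, none or still open, it means among the compounds named here.

Compound 3 `COc1cc2nc(N3CCN(S(=O)(=O)c4ccc(Br)cc4)CC3)nc(N)c2cc1OC` was tested in a functional assay on PC-3 cells (Homo sapiens) for inhibition (on this read-out higher numbers stand for weaker inhibition and lower numbers for stronger inhibition), and gave 20000 nM. Among the two numbers available it stands as the lowest; the nearest neighbour is compound 1 `COc1cc2nc(N3CCN(C(=O)c4ccc(C(C)(C)C)cc4)CC3)nc(N)c2cc1OC` at 47000 nM, a gap that lies beyond the scatter. Compound 2 `COc1cc2nc(N3CCN(C(=O)c4ccc(C(F)(F)F)cc4)CC3)nc(N)c2cc1OC` yielded only a limit, > 100000 nM, and is therefore a boundary rather than a number; this is the boundary described by the limit of > 100000 nM in this assay, at which 1 of the 3 values shown sits.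

Among the compounds with values here, the one measured step, an at least 2.1-fold higher number from compound 1 to compound 2 (0.32 log units; beyond the scatter), concerns the amide-linked pair and a different exchange of groups, so it bears on the present question only loosely, showing that a swap of one group for another of similar size on this aryl ring can move the read-out by a modest amount or more.

Compound 4 `COc1cc2nc(N3CCN(S(=O)(=O)c4ccc(C)cc4)CC3)nc(N)c2cc1OC` differs from compound 3 by methyl in place of bromo on an aromatic carbon. Within the data shown here, no measured step covers this exchange directly. The expectation for compound 4 is a step of a 1.5-fold higher number from compound 3 to compound 4 (0.18 log units; within the scatter), most likely within or just beyond the scatter, toward a somewhat higher number. Compound 4 is therefore estimated at 30000 nM, with a range from 10000 nM to 90000 nM.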

Compound 4, half-maximal inhibitory concentration: 30000 nM
Compound 4: middle estimate and measured number agree at the digits printed; the range from low to high includes it.
By their numbers in this assay, from the lowest: compounds 3, 4 and 1 (each within the scatter of the next, the first and the last beyond it). At a limit, above all of these: compound 2.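

Within the data shown here, the step of a 1.5-fold higher number from compound 3 to compound 4 (0.18 log units; within the scatter) in this assay is the first direct reading of an exchange on the sulfonyl-linked aryl ring, at the aromatic carbon para to a large group, and it shows that bromo and methyl cannot be told apart at this place. Among these compounds, the only earlier step, an at least 2.1-fold higher number from compound 1 to compound 2 (0.32 log units; beyond the scatter), came from the amide-linked pair and lay beyond the scatter, so the new pair adds a case in which an exchange on such a ring leaves no readable difference, although the groups exchanged are not the same and the two steps cannot be set against each other as a rule. No measured property of bromo or methyl is at hand to account for this result.

Going by these compounds, whether an amine, a carboxylic acid or a longer chain on this aromatic carbon would give a number beyond the scatter from that of compound 3 stays open. Also open, on these data alone, is whether the same exchange of bromo for methyl would read alike on the amide-linked compounds, where only tert-butyl and trifluoromethyl appear at that place.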